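Trimming a Methyl Group from Compound 1

A few compounds are considered here, and "the series" means these few. Any claim that something is new, unique, unknown or untested is made for them only; others in the source may bear on it.

The three measured compounds and their values:
compound 1 `Cc1ccc(/C=C/C(=O)Nc2nnc(-c3ccc(Cl)cc3)s2)cc1`: 1.44 ug/mL
compound 2 `COc1ccc(/C=C/C(=O)Nc2nnc(-c3ccc(C)cc3)s2)cc1`: 0.35 ug/mL
compound 3 `Cc1ccc(/C=C/C(=O)Nc2nnc(-c3ccc(C)cc3)s2)cc1`: 0.61 ug/mL

In a functional assay on MCF7 cells (Homo sapiens) for antiproliferative activity, read by MTT assay, with a stated time of 48 h (a lower number here means a stronger inhibitor, a higher number a weaker inhibitor), compound 1 stands with the highest number of the three; it sits a 2.4-fold lower number from compound 1 to compound 3 (0.37 log units; beyond the scatter), and its gap to compound 2 is wider still. Among the measured compounds shown here, only one other step is known, a 1.7-fold higher number from compound 2 to compound 3 (0.24 log units; within the scatter), and that one lies within the scatter.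

Compound 4 `O=C(/C=C/c1ccccc1)Nc1nnc(-c2ccc(Cl)cc2)s1` differs from compound 1 in a single place: hydrogen in place of methyl on an aromatic carbon. For the measured compounds named here, no measured pair shows exactly this change. The step from compound 1 to compound 3 concerns a different ring and a different exchange, so it says little here. The step from compound 2 to compound 3 sits on the same ring as the change to compound 4, and it stayed within the scatter, which suggests that small changes at this position do not move the number much. A step of a 1.3-fold higher number from compound 1 to compound 4 (0.10 log units; within the scatter) is therefore expected, essentially none beyond the scatter. Compound 4 is estimated at 1.8 ug/mL, within 0.8 ug/mL to 4 ug/mL.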

Compound 4, half-maximal inhibitory concentration: 1.42 ug/mL
Compound 4: middle estimate off by 1.3-fold (0.10 log units), on the high side, within the range that was stated.
By their numbers in this assay, from the lowest: compounds 2 and 3 (each within the scatter of the next); then compounds 4 and 1 (each within the scatter of the next).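

The step of a 1.0-fold lower number from compound 1 to compound 4 (0.01 log units; within the scatter) shows that in this assay going from 4-methylphenyl to phenyl, with the rest of compound 1 kept, leaves the number unchanged within the scatter. The earlier compounds shown here offered only an exchange of one group for another at this place, methyl in place of methoxy between compound 2 and compound 3, whereas this pair shows that the methyl group of compound 1 can go altogether, leaving only hydrogen, without a change beyond the scatter. No separate measurement bears on this result.

The compounds shown leave open whether an amine, a carboxylic acid or a longer chain at this place would also leave the number unchanged. They also leave open whether hydrogen in place of methyl would prove equally silent in the setting of compound 3.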